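This account rests on a few compounds, and the source may have more. Where it says the series, first, only, none or still open, it means among the compounds named here.

Of the compounds shown here, three have so far been measured in a functional assay on MDA-MB-435 cells (Homo sapiens) for cytotoxicity, read by MTT assay, with a stated time of 72 h; a higher number here means a weaker inhibitor, a lower number a stronger inhibitor. Compound 1, `Nc1ccc(Nc2c(C(=O)NCc3ccc(F)cc3)nc(Br)c3cccnc23)cc1`, gives 7000 nM in this assay. Compound 3, `O=CNCCCCCCNc1nc(C(=O)NCc2ccc(F)cc2)c(O)c2ncccc12`, gives 16000 nM. For compound 2, `COC(=O)c1nc(Br)c2cccnc2c1N[C@H]1CC[C@H](N)CC1`, this assay reports only a limit, > 20000 nM, and no number. Among the two numbers that are available, compound 1 stands lowest; compound 3 comes nearest, and the gap between them lies beyond the usual scatter of repeated measurements.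

The next compound, compound 4, is `COC(=O)CNc1c(C(=O)NCc2ccc(F)cc2)nc(Br)c2cccnc12`. It differs from compound 1 in one place: (methoxycarbonyl)methyl in place of 4-aminophenyl on a nitrogen on an aromatic ring.

Going by the values given here, no pair of measured compounds isolates this change, so its size is not known from the data. What can be said is that compound 3, whose ring nitrogen carries a chain rather than an aromatic ring, gives 16000 nM and so falls short of compound 1. Compound 2, which carries a methyl ester, reaches only the limit (the limit of > 20000 nM in this assay, at which 1 of the 3 values shown sits). On this basis the step from compound 1 to compound 4 is expected to weaken inhibition, by roughly a 2.1-fold higher number from compound 1 to compound 4 (0.33 log units; beyond the scatter), though the direction is uncertain. Compound 4 is therefore estimated at 15000 nM in this assay, with an expected range from 5000 nM to 40000 nM.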

Compound 4, half-maximal inhibitory concentration: 10000 nM
The estimate for compound 4 lay 1.5-fold (0.18 log units) above the measured number; the measured number falls inside the stated range.
By their numbers in this assay, from the lowest: compounds 1, 4 and 3 (each within the scatter of the next, the first and the last beyond it). At a limit, above all of these: compound 2.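

Going by these compounds alone, replacing 4-aminophenyl with (methoxycarbonyl)methyl on a nitrogen on an aromatic ring in this assay gives a 1.4-fold higher number from compound 1 to compound 4 (0.15 log units; within the scatter), the first direct reading of a change at this position with the rest of the molecule held constant. For this one pair, then, losing the six-membered aromatic ring and the hydrogen-bond donor of the 4-aminophenyl group, and gaining an ester with no ring, produces no change that can be told apart from the scatter of repeated measurements, so an aromatic ring on this nitrogen is not needed to keep the number of compound 1 within that scatter. Within the data shown here, nothing measured so far explains why the two groups read alike, and no available evidence bears on this step.

A single pair cannot show whether this tolerance extends to other groups on the same nitrogen, such as a carboxylic acid in place of the methyl ester, a simple aliphatic amine or a longer chain, any of which might move the number beyond the scatter. It also leaves open whether the same exchange would read alike if the bromine or the 4-fluorobenzyl amide of the shared core were replaced.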